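Half-life notes: from compound 2 to compound 3

This account rests on a few compounds, and the source may have more. Where it says the series, first, only, none or still open, it means among the compounds named here.

Compound 1 `CC(C)(O)c1ccn2c(-c3ccc(F)c(-c4cccnc4)c3)cnc2n1`: 1.7 h
Compound 2 `CC(C)(O)c1cnn2c(-c3ccc(F)c(-c4ncc(F)cc4F)c3)cnc2n1`: 22 h

In an in vivo ADME assay on the whole organism (strain Sprague-Dawley) for metabolic stability, with Rattus norvegicus as the target, at a dose of 1 mg/kg (on this read-out lower numbers stand for a shorter-lived compound and higher numbers for a longer-lived compound), compound 2 stands highest at 22 h, and compound 1 gives 1.7 h. The gap between these two compounds lies beyond the scatter. Compound 3 `CC(C)(O)c1cnn2c(-c3ccc(F)c(-c4ncccc4C#N)c3)cnc2n1` has 3-cyanopyridin-2-yl in place of 3,5-difluoropyridin-2-yl on an aromatic carbon. Within the data shown here, no measured pair isolates this change, because compound 1 and compound 2 differ in more than one place, so the expectation is loose. A moderate shortening is expected, only slightly beyond the scatter. The estimated step is a 2.2-fold lower number from compound 2 to compound 3 (0.34 log units; beyond the scatter). For compound 3 the expected half-life is 10 h, with an estimated range of 3 h to 25 h.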

Compound 3, half-life: 7.9 h
Estimate against measurement, compound 3: 1.3-fold (0.10 log units) above; measured number inside the range.
By their numbers in this assay, from the lowest: compound 1; then compound 3; then compound 2.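

Among these compounds, replacing 3,5-difluoropyridin-2-yl with 3-cyanopyridin-2-yl on this aromatic carbon, ortho to a fluoro group, gives a 2.8-fold lower number from compound 2 to compound 3 (0.44 log units; beyond the scatter) in this assay and is the first single-place comparison. The half-life at this position therefore responds to the ring substituents, though the step is modest. Nothing available explains the step.

Still open, from the compounds shown here alone, is where a pyridin-2-yl ring carrying a methoxy group or an amine would fall relative to compound 2 and compound 3. Whether the same replacement gives a similar step on the core of compound 1 is also unresolved.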